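From Dimethylsulfamoyl to Cyano on a Shared Core

This account rests on a few compounds, and the source may have more. Where it says the series, first, only, none or still open, it means among the compounds named here.

In a functional assay on Huh-5-2 cells (Homo sapiens), read by MTT assay (on this read-out lower numbers stand for higher toxicity in this test and higher numbers for lower toxicity in this test), compound 2 `CN(C)S(=O)(=O)c1ccc(-c2ccc(Cl)cc2)c(COc2ccc(-c3nc4cc(C(=O)O)ccc4n3C3CCCCC3)cc2)c1` gives 26000 nM and compound 1 `O=C(O)c1ccc2c(c1)nc(-c1ccc(OCc3cc(Cl)ccc3-c3cccc(Cl)c3)cc1)n2C1CCCCC1` gives 32000 nM so the two values lie within the usual scatter of each other and neither can be ranked above the other. Among the compounds with values here, compound 3 `N#Cc1ccc(-c2ccc(Cl)cc2)c(COc2ccc(-c3nc4cc(C(=O)O)ccc4n3C3CCCCC3)cc2)c1` has no measurement yet and differs from compound 2 in one place: cyano in place of dimethylsulfamoyl on an aromatic carbon para to a 4-chlorophenyl group. Within the data shown here, no measured pair shows this swap on its own, so the data offer only a thin guide. With compound 2 at 26000 nM as the starting point, no step beyond the scatter is expected in this assay for this swap. The estimated 1.2-fold higher number from compound 2 to compound 3 (0.06 log units; within the scatter) is therefore small and could go either way. For compound 3 the estimate is 30000 nM with an expected range from 12000 nM to 70000 nM as its upper end.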

Compound 3, half-maximal cytotoxic concentration: 23000 nM
Estimate against measurement, compound 3: 1.3-fold (0.12 log units) above; the range from low to high includes it.
By their numbers in this assay, from the lowest: compounds 3, 2 and 1 (each within the scatter of the next).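

In this assay the swap of dimethylsulfamoyl for cyano brings a 1.1-fold lower number from compound 2 to compound 3 (0.05 log units; within the scatter) and so gives a direct reading of a single change at this aromatic carbon, para to a 4-chlorophenyl group. At this position, in this test, a group with far fewer heavy atoms and no sulfur takes the place of the larger one with no step beyond the scatter. Nothing measured here explains this outcome, so no cause can be given for it. On these data alone, whether a primary amine or a methoxy group on the same carbon would also stay within the scatter remains open. As far as these compounds go, one pair also sets no pattern, so it is unknown whether the same swap would read alike on a different core.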